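Solubility notes: amide for triazole at the para position

The compounds below may be only part of what the source reports. "The series", "measured", "known", "first", "only" and "open" are said of these compounds alone.

Measured so far in a physicochemical assay for solubility, read by nephelometry, in phosphate buffer, measured as kinetic solubility, at pH 6.5; a lower number here means a less soluble compound, a higher number a more soluble compound:
compound 1 `COc1ccc(-c2cc(-c3ccc(S(=O)(=O)NC4CC4)cc3)cnc2N)cn1`: 6.3 ug/mL
compound 2 `COc1ccc(-c2cc(-c3ccc(S(C)(=O)=O)cc3C(F)(F)F)cnc2N)cn1`: 12.5 ug/mL
compound 3 `COc1ccc(-c2cc(-c3ccc(-n4cncn4)cc3)cnc2N)cn1`: 6.3 ug/mL

Compound 3 and compound 1 return the same number in this assay, and these are the two smallest of the three values; compound 2 differs from them only within the scatter, so no order among the three can be read from these data.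

Within the data shown here, the one single-point step measured so far is that from compound 1 to compound 3, in which a 1H-1,2,4-triazol-1-yl group took the place of cyclopropylsulfamoyl on an aromatic carbon: no change at the digits printed from compound 1 to compound 3 (within the scatter).

Compound 4 `CNC(=O)c1ccc(-c2cnc(N)c(-c3ccc(OC)nc3)c2)cc1` is the next analogue. It differs from compound 3 as follows: methylcarbamoyl in place of 1H-1,2,4-triazol-1-yl on an aromatic carbon. Among the measured compounds shown here, no measured step involves methylcarbamoyl, so the only bearing evidence is indirect: the exchange at this same aromatic carbon that gave compound 3 from compound 1 left the number unchanged within the scatter. On that basis the step from compound 3 to compound 4 is expected to be a 1.3-fold higher number from compound 3 to compound 4 (0.10 log units; within the scatter), that is, nothing beyond the scatter in either direction. For the measured compounds named here, compound 4 is therefore estimated at 8 ug/mL in this assay, with a range from 3 ug/mL to 22 ug/mL; the range is wide because the entering group has no precedent among the measured compounds.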

Compound 4, solubility: 50 ug/mL
The estimate for compound 4 lay 6.3-fold (0.80 log units) below the measured number; the whole stated range lies below it.
By their numbers in this assay, from the lowest: compounds 1, 3 and 2 (each within the scatter of the next); then compound 4.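

In this assay, the aromatic carbon para to a large group turns out to be able to move the number. Methylcarbamoyl in place of 1H-1,2,4-triazol-1-yl gives a 7.9-fold higher number from compound 3 to compound 4 (0.90 log units; beyond the scatter), and methylcarbamoyl in place of cyclopropylsulfamoyl gives a 7.9-fold higher number from compound 1 to compound 4 (0.90 log units; beyond the scatter), whereas the earlier exchange at this same carbon gave no change at the digits printed from compound 1 to compound 3 (within the scatter), so the first two groups alone gave no sign of this range. The change removes a five-membered aromatic ring with 0 hydrogen-bond donors and brings in a group with no ring and 1 hydrogen-bond donor, but nothing available ties the higher number to either of these differences.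

As far as these compounds go, it remains open which part of methylcarbamoyl goes with the higher number: the amide hydrogen, the carbonyl or the methyl. A primary carboxamide, a dimethylcarbamoyl group or a carboxylic acid on this carbon would help to separate those parts, and a longer chain on the amide nitrogen would show how far the number holds as the group grows.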